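The source may hold more compounds than are shown below. What is called first, only, known or untested is meant among the compounds shown, and "the series" means these compounds.

Compound 1 `COc1cc2c(c(O)c1C(=O)/C=C/c1ccc(OC(=O)c3cccs3)cc1)CCC(C)(C)O2`: in an assay on HEK293T cells for inhibition of nuclear factor NF-kappa-B complex (Homo sapiens), read by a luciferase reporter (a higher number here means a weaker inhibitor, a lower number a stronger inhibitor), compound 1 gives > 30000 nM, a limit of the assay rather than a number.
Compound 2 `COc1cc2c(c(O)c1C(=O)/C=C/c1ccc(OC(=O)c3cccc(Br)c3)cc1)CCC(C)(C)O2`: in this assay compound 2 gives > 30000 nM, also a limit.

For the measured compounds named here, compound 2 therefore stands only at a limit, and the one measured step that the two limits leave unreadable from compound 1 to compound 2 cannot be sized, since (the limit of > 30000 nM in this assay, at which 2 of the 2 values shown sit). Compound 3 `C=CC(=O)Oc1ccc(/C=C/C(=O)c2c(OC)cc3c(c2O)CCC(C)(C)O3)cc1` differs from compound 2 by vinyl in place of 3-bromophenyl on a carbonyl carbon. No readable step bears on this change. The expected step of a number no higher from compound 2 to compound 3 (the limit leaves the size open) is accordingly set at none beyond the scatter, with a limit again the likeliest outcome. Compound 3 is estimated at 30000 nM, in the range 8000 nM to 100000 nM.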

Compound 3, half-maximal inhibitory concentration: 8990 nM
Estimate against measurement, compound 3: 3.3-fold (0.52 log units) above; measured number inside the range.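

Changing the group on this carbonyl carbon can move the reading in this assay: vinyl in place of 3-bromophenyl gives an at least 3.3-fold lower number from compound 2 to compound 3 (0.52 log units; beyond the scatter), and vinyl in place of thiophen-2-yl gives an at least 3.3-fold lower number from compound 1 to compound 3 (0.52 log units; beyond the scatter). These are the first readable steps at this position, and their true size stays open, as does the step between compound 1 and compound 2, which cannot be read: the limit of > 30000 nM in this assay, at which 2 of the 3 values shown sit.

The compounds shown leave open whether the double bond of vinyl matters. An ethyl group, a longer chain or an amine on this carbonyl carbon would bear on that question.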